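A Methoxy in Place of a Methyl on Compound 3

The source may hold more compounds than are shown below. What is called first, only, known or untested is meant among the compounds shown, and "the series" means these compounds.

The three compounds measured so far in a functional assay on DU-145 cells (Homo sapiens) for cytotoxicity, read by MTT assay, with a stated time of 72 h (a higher number here means that more compound is needed for the effect, a lower number that less compound is needed), are:
Compound 1 `O=c1cc(Nc2ccccc2)cc(-c2ccccc2)o1` gives 0.098 uM.
Compound 2 `CCCCCc1cc(Nc2ccc(OC)cc2)cc(=O)o1` gives 5.94 uM.
Compound 3 `Cc1ccc(Nc2cc(-c3ccccc3)oc(=O)c2)cc1` gives 0.073 uM.

Compound 3 shows the lowest number of the three, but compound 1 stands nearest and within the scatter, so the two cannot be ranked against each other; compound 2 is furthest and beyond the scatter. Among the measured compounds shown here, the only step between compounds that differ in one place is a 1.3-fold lower number from compound 1 to compound 3 (0.13 log units; within the scatter), a change within the scatter.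

Compound 4 `COc1ccc(Nc2cc(-c3ccccc3)oc(=O)c2)cc1` differs from compound 3 in one place: methoxy in place of methyl on an aromatic carbon. For the measured compounds named here, no measured step covers this exchange. Going by the values given here, compound 2 carries a methoxy on the same ring, yet it also differs from compound 4 in the group on the shared core, so its value can only be noted and gives no step. Among the compounds with values here, with the one measured step at this position within the scatter, compound 4 is expected to move little: a 1.4-fold higher number from compound 3 to compound 4 (0.14 log units; within the scatter) is the estimated step. Compound 4 is therefore estimated at 0.1 uM, with a range from 0.03 uM to 0.35 uM.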

Compound 4, concentration for half-maximal effect: 0.12 uM
The estimate for compound 4 lay 1.2-fold (0.08 log units) below the measured number; the measured number falls inside the stated range.
By their numbers in this assay, from the lowest: compounds 3, 1 and 4 (each within the scatter of the next); then compound 2.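

In this assay, the aromatic carbon para to a large group now has methoxy compared with both methyl (a 1.6-fold higher number from compound 3 to compound 4 (0.22 log units; within the scatter)) and hydrogen (a 1.2-fold higher number from compound 1 to compound 4 (0.09 log units; within the scatter)). Both steps lie within the scatter, so hydrogen, methyl and methoxy cannot be ranked at this position, and the added oxygen leaves no readable change in the number. The large change lies at the other place, where, with methoxy held fixed, phenyl replaces pentyl (a 50-fold lower number from compound 2 to compound 4 (1.69 log units; beyond the scatter)), a step well beyond the scatter.

Still open, on these data alone, is whether a different group at the first position, such as an amine or a carboxylic acid, would move the number beyond the scatter, and whether a benzyl or a shorter chain in place of phenyl would keep it low. Nothing available explains either the flat steps or the large one.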